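A few compounds are considered here, and "the series" means these few. Any claim that something is new, unique, unknown or untested is made for them only; others in the source may bear on it.

Measured so far:
- compound 1 `Cc1ccc(S(=O)(=O)c2cnc3ccc(C)cc3c2N2CCC(C)CC2)cc1` gives 82% in an assay on isolated protein for displacement of a labelled ligand from metabotropic glutamate receptor 5 (Homo sapiens), with a stated time of 60 min, tested at 1 uM; a lower number here means less inhibition, a higher number more inhibition at the concentration tested (going by the name of the read-out)
- compound 2 `COc1ccc(S(=O)(=O)c2cnc3ccc(C)cc3c2N2CCC(C)CC2)cc1Cl` gives 93% in this assay

Compound 2 stands highest of the two numbers; its nearest neighbour, compound 1, sits lower by a number 11 percentage points higher from compound 1 to compound 2 (beyond the scatter), a modest step beyond the scatter.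

Compound 3 `Cc1cc(C)cc(S(=O)(=O)c2cnc3ccc(C)cc3c2N2CCC(C)CC2)c1` has not been measured in this assay. The change from compound 2 to compound 3 is 3,5-dimethylphenyl in place of 3-chloro-4-methoxyphenyl on a sulfonyl sulfur. Within the data shown here, only one step bears on the sulfonyl aryl position: from compound 1 to compound 2, where the 3-chloro-4-methoxyphenyl in place of 4-methylphenyl gave a number 11 percentage points higher from compound 1 to compound 2 (beyond the scatter). Compound 3 returns to an aryl group carrying only methyl groups, closer to compound 1 than to compound 2, so a step back toward compound 1 is expected, of about a number 8 percentage points lower from compound 2 to compound 3 (within the scatter), which would lie within the scatter. Compound 3 is therefore expected to give about 85% in this assay, with a range of 70% to 95%.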

Compound 3, a percentage reported as inhibition, at one concentration (the size of the read-out at that concentration, not a potency): 80%
Beside the measured number, compound 3's estimate is 5 percentage points above it, within the range that was stated.
By their numbers in this assay, from the lowest: compounds 3 and 1 (each within the scatter of the next); then compound 2.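

In this assay, 3,5-dimethylphenyl in place of 3-chloro-4-methoxyphenyl on the sulfonyl sulfur gives a number 13 percentage points lower from compound 2 to compound 3 (beyond the scatter), while 3,5-dimethylphenyl in place of 4-methylphenyl gives a number 2 percentage points lower from compound 1 to compound 3 (within the scatter), so the two aryl groups carrying only methyl groups cannot be told apart here. Among these three compounds, 3-chloro-4-methoxyphenyl alone stands apart, and its advantage now holds against two methyl-substituted aryl groups rather than one, with no compound shown going against this. Nothing available accounts for the difference.

From the compounds shown here alone, the chlorine and the methoxy group always change together here, so their separate contributions remain open; 3-chlorophenyl and 4-methoxyphenyl would separate them. Going by these compounds, how an aryl group carrying an amine or a carboxylic acid would read at this position also remains open.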